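The source may report more compounds than this note shows. Statements on the series, on what has been measured and on what is new or still open speak of the compounds shown alone.

Compound 1 `CC(C)(C)c1cc(C(=O)NC2CCN(Cc3ccccc3)CC2)cc(C(C)(C)C)c1O`: 85100 nM
Compound 2 `CC(C)(C)c1cc(/C=C/C(=O)NC2CCN(Cc3ccccc3)CC2)cc(C(C)(C)C)c1O`: 33500 nM
Compound 3 `CC(C)(C)c1cc(/C=C/C(=O)NCCC2CCN(Cc3ccccc3)CC2)cc(C(C)(C)C)c1O`: 8500 nM

Of the compounds shown here, three have been measured in an assay on isolated protein for inhibition of Amine oxidase [flavin-containing] B (Homo sapiens), read by fluorescence, with stated times of 15 min and 20 min; a lower number here means a stronger inhibitor, a higher number a weaker inhibitor. Compound 3 has the lowest number of the three: compound 2 comes nearest, and compound 1 lies furthest away, both gaps beyond the usual scatter of this assay. Compound 4 `CC(C)(C)c1cc(/C=C/C(=O)NCCC2CCN(Cc3ccccc3Cl)CC2)cc(C(C)(C)C)c1O` has not yet been measured. It differs from compound 3 in one place, (chloro in place of hydrogen on an aromatic carbon), that is, phenyl becomes 2-chlorophenyl. Among the compounds with values here, a single chlorine added on the aromatic ring is a small change, and no measured pair here shows what it does. The step from compound 3 to compound 4 is expected to be modest, a 1.4-fold lower number from compound 3 to compound 4 (0.15 log units; within the scatter), slightly toward a lower number. Compound 4 is therefore estimated at 6000 nM, within a range of 2000 nM to 20000 nM.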

Compound 4, half-maximal inhibitory concentration: 9800 nM
Compound 4: middle estimate off by 1.6-fold (0.21 log units), on the low side; low and high end bracket the measured number.
By their numbers in this assay, from the lowest: compounds 3 and 4 (each within the scatter of the next); then compound 2; then compound 1.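

In this assay, within the data shown here, chloro in place of hydrogen on an aromatic carbon gives a 1.2-fold higher number from compound 3 to compound 4 (0.06 log units; within the scatter) and so offers the first reading at this position. Within the scatter, phenyl and 2-chlorophenyl cannot be told apart, and this position takes a chlorine without a step beyond it. Nothing available explains this result. On these data alone, whether a fluoro, methoxy or nitrile group in the same place would read differently stays open. So does whether the same change on compound 2, with its different chain, would give a similar step.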